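The compounds below may be only part of what the source reports. "The series", "measured", "known", "first", "only" and "open" are said of these compounds alone.

Values in a functional assay on SGC-7901 cells (Homo sapiens) for antiproliferative activity, read by MTT assay, with a stated time of 72 h; a higher number here means a weaker inhibitor, a lower number a stronger inhibitor:
Compound 1 `CCOc1ccc(-c2ccc3ncn(-c4cc(OC)c(OC)c(OC)c4)c3c2)cc1`: 2970 nM
Compound 2 `COc1cc(-n2cnc3ccc(-c4ccccc4Cl)cc32)cc(OC)c1OC`: > 10000 nM (a limit of the assay, not a number)
Compound 3 `COc1cc(-n2cnc3ccc(-c4cccc(F)c4)cc32)cc(OC)c1OC`: 2490 nM

Among the compounds with values here, compound 3 gives 2490 nM, and no measured compound sits clearly lower. Within the data shown here, its one close neighbour appears in the step of a 1.2-fold lower number from compound 1 to compound 3 (0.08 log units; within the scatter). Compound 4 `COc1cc(-n2cnc3ccc(-c4ccc(O)cc4)cc32)cc(OC)c1OC` carries 4-hydroxyphenyl in place of 3-fluorophenyl on an aromatic carbon. Swapping the group at this place can matter, as the 2-chlorophenyl group shows: an at least 4.0-fold lower number from compound 2 to compound 3 (0.60 log units; beyond the scatter). The closer match to the entering group is 4-ethoxyphenyl, and compound 1, which carries it, gives 2970 nM, so little change is expected in this assay. The expected step is a 1.4-fold higher number from compound 3 to compound 4 (0.15 log units; within the scatter), with no shift beyond the scatter anticipated. For compound 4 the estimated value is 3500 nM, with an expected range of 900 nM to 10000 nM.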

Compound 4, half-maximal inhibitory concentration: > 10000 nM
Compound 4 ended at the assay's limit; the forecaster's own chance of this, stated with the estimate: 25%; middle value at least 2.8-fold (0.45 log units) away from the limit.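

In this assay, compound 4 stands at a limit of the assay, not a number, so the 4-hydroxyphenyl group is not an equal swap at this position. Removing only the ethyl from the oxygen is enough to matter, with an at least 3.3-fold higher number from compound 1 to compound 4 (0.52 log units; beyond the scatter), and the change from 3-fluorophenyl gives an at least 4.0-fold higher number from compound 3 to compound 4 (0.60 log units; beyond the scatter). The step between compound 2 and compound 4 cannot be read, because both values are limits: the limit of > 10000 nM in this assay, at which 2 of the 4 values shown sit.

As far as these compounds go, how much of the oxygen's substituent is needed stays open. A 4-methoxyphenyl or a 4-aminophenyl group at this place would speak to that.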